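This account rests on a few compounds, and the source may have more. Where it says the series, first, only, none or still open, it means among the compounds named here.

Measured in an ADME assay on BJ cells (Homo sapiens) for cytotoxicity, with a stated time of 72 h (a higher number here means that more compound is needed for the effect, a lower number that less compound is needed), so far, each entry a limit of the assay:
compound 1 `C=C[C@@](C)(/C=C/c1ccc(OC)cc1)CCC=C(C)C` gives > 36600 nM as a limit
compound 2 `C=C[C@@](C)(/C=C/c1ccc(OS(=O)(=O)C(F)(F)F)cc1)CCC=C(C)C` gives > 36600 nM as a limit
compound 3 `C=C[C@@](C)(/C=C/c1ccc(OS(=O)(=O)c2ccc(C)cc2)cc1)CCC=C(C)C` gives > 36600 nM as a limit

Compound 2 has no number of its own, only a limit, and the other two entries are limits as well. Within the data shown here, the series so far offers the limit of > 36600 nM in this assay, at which 3 of the 3 values shown sit, and no exact value.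

Next is compound 4 `C=C[C@@](C)(/C=C/c1ccc(Nc2ccc(OC)cc2)cc1)CCC=C(C)C` with this structural change: (4-methoxyphenyl)amino in place of ((trifluoromethyl)sulfonyl)oxy on an aromatic carbon and so (4-methylphenyl is not involved here) the new group, (4-methoxyphenyl)amino, stands in place of ((trifluoromethyl)sulfonyl)oxy on an aromatic carbon.

Among the measured compounds shown here, two measured steps bear on this change. They are a step that the two limits leave unreadable from compound 1 to compound 2 and a step that the two limits leave unreadable from compound 2 to compound 3 and neither has a size that can be carried over.

The expectation therefore rests on compound 2, whose > 36600 nM is a limit. In this assay the estimate is an at least 1.0-fold lower number from compound 2 to compound 4 (0.00 log units; that floor lies within the scatter) and no shift in either direction beyond the scatter is expected. A report of compound 4 as a limit again would fit this expectation. For compound 4 the estimated value is 36000 nM with an expected range from 15000 nM to 80000 nM.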

Compound 4, half-maximal effective concentration: > 36600 nM
Compound 4: a limit, no number; the forecaster's own chance of this, stated with the estimate: 65%; middle value at least 1.0-fold (0.00 log units) from the limit.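

In this assay, among these compounds, compound 4 gives > 36600 nM, a limit, so no step to compound 4 from compound 1 or compound 2 can be read. The compounds shown leave open whether any of these groups on the shared core changes the half-maximal effective concentration at all, and by how much: the limit of > 36600 nM in this assay, at which 4 of the 4 values shown sit.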